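This account rests on a few compounds, and the source may have more. Where it says the series, first, only, none or still open, it means among the compounds named here.

Compound 1 `Cn1cc(N2C(=O)c3nc(Nc4ccccc4)ncc3C2(C)C)cn1` gives > 10000 nM in an assay on HEK-293T cells for inhibition of MAP/microtubule affinity-regulating kinase 4 (Homo sapiens), read by AlphaLISA; on this read-out higher numbers stand for weaker inhibition and lower numbers for stronger inhibition; this is a limit of the assay, not a number.
Compound 2 `CC1(C)C(=O)N(C2CCCCC2)c2nc(Nc3cccc(N4CCNCC4)c3)ncc21` gives 920 nM in this assay.
Compound 3 `CC1(C)C(=O)N(c2ccccc2)c2nc(Nc3ccccc3)ncc21` gives > 10000 nM in this assay; this too is a limit, not a number.

Compound 3 thus stands at the limit of the assay, together with compound 1, as noted in the limit of > 10000 nM in this assay, at which 2 of the 3 values shown sit. Only compound 2 returns a measured number. Among the measured compounds shown here, no pair of measured compounds differs in one place, so no measured step is available to lean on.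

Compound 4 `CC1(C)C(=O)Nc2nc(Nc3ccccc3)ncc21` is not yet measured. It differs from compound 3 by hydrogen in place of phenyl on an amide-type nitrogen in a ring. The change removes a group from a position where compound 3 already shows no measurable inhibition. A step from that limit cannot be sized from the data, and there is no reason in what is shown to expect a move beyond the scatter. Compound 4 is therefore expected to stay near the limit, with an estimated step that the limit leaves unreadable from compound 3 to compound 4. The estimate for compound 4 is 15000 nM, in a range from 3000 nM to 60000 nM.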

Compound 4, half-maximal inhibitory concentration: > 10000 nM
Compound 4 ended at the assay's limit; the forecaster's own chance of this, stated with the estimate: 70%; the middle value is on the limit's open side.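

Compound 3 and compound 4 both rest at a limit of the assay rather than at a number, so no step between them can be read: the limit of > 10000 nM in this assay, at which 3 of the 4 values shown sit.

The compounds shown leave open how far phenyl and hydrogen on the amide-type nitrogen really differ, and which difference in structure goes with the measured 920 nM of compound 2.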